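The source may report more compounds than this note shows. Statements on the series, on what has been measured and on what is new or still open speak of the compounds shown alone.

In a functional assay on MC-38 cells (Mus musculus) for antiproliferative activity, read by CCK-8 assay, with a stated time of 48 h (a higher number here means a weaker inhibitor, a lower number a stronger inhibitor), compound 1 `COc1ccc(/C=C\c2cc(OC)c(OC)c(OC)c2)cc1OCc1ccc(CN2C[C@H](O)C[C@@H]2C(=O)O)cc1` gives > 10000 nM, which is a limit of the assay and not a number. For the measured compounds named here, compound 2 `COc1ccc(/C=C\c2cc(OC)c(OC)c(OC)c2)cc1OCc1ccc(CNCCO)cc1` gives 1200 nM, the only true number so far. Compound 3 `COc1ccc(/C=C\c2cc(OC)c(OC)c(OC)c2)cc1OCc1ccc(CN2CC(C(=O)O)C2)cc1` keeps the shared core but changes one group: 3-carboxyazetidin-1-yl in place of (2-hydroxyethyl)amino on a saturated chain carbon bound to an aromatic carbon. The new 3-carboxyazetidin-1-yl again carries a carboxy group, as does the 2-carboxy-4-hydroxypyrrolidin-1-yl of compound 1. Going by the values given here, only one measured step bears on this change: an at least 8.3-fold lower number from compound 1 to compound 2 (0.92 log units; beyond the scatter). That step ran the opposite way, removing the carboxy-bearing ring, so a move back towards compound 1 is expected to raise the number in this assay, though the smaller ring may not go as far. The expected change is a 5.8-fold higher number from compound 2 to compound 3 (0.77 log units; beyond the scatter). For compound 3 the estimated value is 7000 nM, with an expected range of 2000 nM to 25000 nM.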

Compound 3, half-maximal inhibitory concentration: > 10000 nM
Compound 3: only a limit was reported; the forecaster's own chance of this, stated with the estimate: 45%; middle value at least 1.4-fold (0.15 log units) from the limit.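

At the saturated chain carbon bound to an aromatic carbon, 3-carboxyazetidin-1-yl in place of (2-hydroxyethyl)amino gives an at least 8.3-fold higher number from compound 2 to compound 3 (0.92 log units; beyond the scatter) in this assay. Compound 2 now stands apart from two different carboxy-bearing rings, so the weaker result is no longer tied to the 2-carboxy-4-hydroxypyrrolidin-1-yl of compound 1 alone. Compound 1 and compound 3 both reach a limit of the assay rather than a number, and the step between them cannot be read: the limit of > 10000 nM in this assay, at which 2 of the 3 values shown sit.

As far as these compounds go, it remains open whether the carboxylic acid or the ring itself goes with the weaker result, a question that a plain azetidin-1-yl or an open chain ending in a carboxylic acid would address. From the compounds shown here alone, how a longer chain ending in a hydroxyl group would compare with compound 2 also remains open.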